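Two Measured Compounds and an Expectation for a Third

The source may hold more compounds than are shown below. What is called first, only, known or untested is meant among the compounds shown, and "the series" means these compounds.

Compound 1 `CC(C)n1cc(Nc2ncc(C3CC3)c(NCCCNC(=O)C3CCC3)n2)cn1` is a potent inhibitor in an assay on isolated protein for inhibition of serine/threonine-protein kinase TBK1 (Homo sapiens) (on this read-out higher numbers stand for weaker inhibition and lower numbers for stronger inhibition), where compound 1 gives 4 nM. Compound 2 `CN(C)Cc1ccc(Nc2ncc(C3CC3)c(NCCCNC(=O)C3CCC3)n2)cc1` keeps the shared core and, in this assay, compound 2 gives 6 nM. The only change between them is a 1.5-fold higher number from compound 1 to compound 2 (0.18 log units; within the scatter), so the two numbers cannot be told apart, and compound 2 stands level with compound 1 on the numbers shown.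

Compound 3 `CN1CCN(C(=O)c2ccc(Nc3ncc(C4CC4)c(NCCCNC(=O)C4CCC4)n3)cc2)CC1` differs from compound 2 at a different position: (4-methylpiperazin-1-yl)carbonyl in place of (dimethylamino)methyl on an aromatic carbon. Within the data shown here, no measured step touches this position; the single measured step concerns the group on the ring nitrogen and was within the scatter. Among the measured compounds shown here, there is therefore no direct precedent, and the expectation rests on the observation that the one substitution made so far left this assay essentially unchanged. A step in either direction that stays within the scatter is expected. Compound 3 is estimated at 8 nM, with a likely range from 3 nM to 25 nM. This estimate corresponds to an expected step of a 1.3-fold higher number from compound 2 to compound 3 (0.12 log units; within the scatter).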

Compound 3, half-maximal inhibitory concentration: 2 nM
The estimate for compound 3 lay 4.0-fold (0.60 log units) above the measured number; the measured number lies below the stated range.
By their numbers in this assay, from the lowest: compounds 3, 1 and 2 (each within the scatter of the next, the first and the last beyond it).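

Swapping (dimethylamino)methyl for (4-methylpiperazin-1-yl)carbonyl on this aromatic carbon, para to a large group, gives in this assay a 3.0-fold lower number from compound 2 to compound 3 (0.48 log units; beyond the scatter) and is a modest change, yet it is the first step shown that rises above the scatter. This position can therefore shift the number, and a larger group with a six-membered non-aromatic ring and a carbonyl can sit there without weakening inhibition in this read-out. The data shown offer no explanation for this gain.

The change alters several things at once, since the carbonyl, the ring and the size of the group all differ between compound 2 and compound 3, so this single step cannot show which of them matters. Two groups not among those shown would separate these features: (4-methylpiperazin-1-yl)methyl would keep the ring and the methylene link of compound 2 without the carbonyl, while (dimethylamino)carbonyl would keep the carbonyl of compound 3 without the ring.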